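A few compounds are considered here, and "the series" means these few. Any claim that something is new, unique, unknown or untested is made for them only; others in the source may bear on it.

Compound 3 `c1cn2cc(-c3ccc4c(c3)ncn4C3CCCCC3)nc(-c3ccc4ncn(C5CCCCC5)c4c3)c2n1` gives 25.6% in a functional assay on UO-31 cells (Homo sapiens) for inhibition, read by sulforhodamine B assay, with a stated time of 48 h, tested at 10 uM; a higher number here means more inhibition at the concentration tested (going by the name of the read-out), a lower number less inhibition. It stands second highest of the three numbers recorded: compound 2 `Fc1ccccc1-c1cn2ccnc2c(-c2ccc3ncn(C4CCCCC4)c3c2)n1` gives 22.9%, a gap within the scatter, while compound 1 `c1ccc(-c2cn3ccnc3c(-c3ccc4ncn(C5CCCCC5)c4c3)n2)cc1` gives 55.2%, beyond it. Within the data shown here, the only measured step, a number 32.3 percentage points lower from compound 1 to compound 2 (beyond the scatter), concerns a fluoro in place of hydrogen on an aromatic carbon and does not touch the ring nitrogen substituent. Compound 4 `c1ccc(Cn2cnc3ccc(-c4nc(-c5ccc6c(c5)ncn6C5CCCCC5)cn5ccnc45)cc32)cc1` differs from compound 3 by benzyl in place of cyclohexyl on an aromatic nitrogen. Among the measured compounds shown here, no measured step bears on this change, so nothing beyond the scatter is expected in this assay, in either direction. Compound 4 is therefore estimated at 28% in this assay, with a range of 10% to 50%. This expectation amounts to a step of a number 2.4 percentage points higher from compound 3 to compound 4 (within the scatter).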

Compound 4, a percentage reported as inhibition, at one concentration (the size of the read-out at that concentration, not a potency): -51.4%
The estimate for compound 4 lay 79.4 percentage points above the measured number; measured number outside the range, below it.
By their numbers in this assay, from the lowest: compound 4; then compounds 2 and 3 (each within the scatter of the next); then compound 1.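

In this assay, among these compounds, the group on this aromatic nitrogen proves decisive: benzyl in place of cyclohexyl gives a number 77 percentage points lower from compound 3 to compound 4 (beyond the scatter), the only measured step at this position. Compound 4 reads -51.4%, so the change carries the read-out below zero rather than just lowering the inhibition. Nothing in hand explains this step.

As far as these compounds go, it remains open whether the aromatic ring or the extra carbon of benzyl is decisive. A simple methyl, or a longer chain ending in an amine, on this nitrogen would help to separate these.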